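Notes on the step from compound 3 to compound 4

The compounds below may be only part of what the source reports. "The series", "measured", "known", "first", "only" and "open" are said of these compounds alone.

Values in a functional assay on PC-3 cells (Homo sapiens) for antiproliferative activity, read by MTT assay, with a stated time of 48 h; a higher number here means a weaker inhibitor, a lower number a stronger inhibitor:
- compound 1 `COc1ccc(CN(C(=O)Cn2cc(COc3ccc4ccc(=O)oc4c3)nn2)c2cc(OC)c(OC)c(OC)c2)cc1`: 860 nM
- compound 2 `COc1ccc(CN(C(=O)Cn2cc(CSC3=NCCS3)nn2)c2cc(OC)c(OC)c(OC)c2)cc1`: 16000 nM
- compound 3 `COc1ccc(CN(C(=O)Cn2cc(CSc3nncs3)nn2)c2cc(OC)c(OC)c(OC)c2)cc1`: 16500 nM

Compound 3 stands at the weak end of the series, with no real gap to its nearest neighbour: a 1.0-fold higher number from compound 2 to compound 3 (0.01 log units; within the scatter). Compound 4 `COc1ccc(CN(C(=O)Cn2cc(Cn3ccc4ccccc43)nn2)c2cc(OC)c(OC)c(OC)c2)cc1` differs from it as follows: 1H-indol-1-yl in place of (1,3,4-thiadiazol-2-yl)sulfanyl on a saturated chain carbon bound to an aromatic carbon. That is 1H-indol-1-yl in place of (1,3,4-thiadiazol-2-yl)sulfanyl on a saturated chain carbon bound to an aromatic carbon.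

The large measured steps are a 19-fold higher number from compound 1 to compound 2 (1.27 log units; beyond the scatter) and a 19-fold higher number from compound 1 to compound 3 (1.28 log units; beyond the scatter), both leaving the two-ring group of compound 1. Compound 4 also carries a two-ring group, though a smaller one, so part of that gap may be recovered in this assay. A lower number is expected: a 5.5-fold lower number from compound 3 to compound 4 (0.74 log units; beyond the scatter). Compound 4 is estimated at 3000 nM, with an expected range of 800 nM to 11000 nM.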

Compound 4, half-maximal inhibitory concentration: 2390 nM
Estimate against measurement, compound 4: 1.3-fold (0.10 log units) above; measured number inside the range.
By their numbers in this assay, from the lowest: compound 1; then compound 4; then compounds 2 and 3 (each within the scatter of the next).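

In this assay 1H-indol-1-yl on the saturated chain carbon bound to an aromatic carbon gives a 6.9-fold lower number from compound 3 to compound 4 (0.84 log units; beyond the scatter) and a 6.7-fold lower number from compound 2 to compound 4 (0.83 log units; beyond the scatter) and so shows that the two-ring group of compound 1 is not the only one here to improve on the single-ring sulfur-linked groups. Still, a 2.8-fold higher number from compound 1 to compound 4 (0.44 log units; beyond the scatter) remains as a gap between the two two-ring groups. No measurement given here bears on the reason for either difference.

Compound 4 changes ring count and removes the sulfur in one step, leaving the two effects unseparated. An amine or phenyl group at this place would test this position further.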